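A few compounds are considered here, and "the series" means these few. Any claim that something is new, unique, unknown or untested is made for them only; others in the source may bear on it.

Compound 1 (`COc1ccc(NS(=O)(=O)c2ccc(N3CCNC3=O)cc2)cc1OC`) and compound 2 (`O=C1NCCN1c1ccc(S(=O)(=O)Nc2cccc(Cl)c2)cc1`) share a core and differ only in the aryl group on the sulfonamide nitrogen. In a functional assay on MCF7 cells (Homo sapiens) for antiproliferative activity, read by sulforhodamine B assay, with a stated time of 48 h (a higher number here means a weaker inhibitor, a lower number a stronger inhibitor), compound 1 gives 610 nM and compound 2 gives 79 nM, so compound 2 holds the lower of the two numbers, by a gap beyond the scatter. Compound 3 (`COc1ccc(NS(=O)(=O)c2ccc(N3CCNC3=O)cc2)cc1`) has not yet been measured. It carries 4-methoxyphenyl in place of 3-chlorophenyl on a sulfonamide nitrogen. Among the compounds with values here, compound 1 also bears methoxy substitution on the group at that nitrogen, and its 610 nM is the only guide to such a group, so a higher number than that of compound 2 is expected in this assay. The expected change is a 3.5-fold higher number from compound 2 to compound 3 (0.55 log units; beyond the scatter), beyond the scatter. For compound 3 the estimated value is 280 nM, with an expected range from 90 nM to 900 nM.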

Compound 3, half-maximal inhibitory concentration: > 1000 nM
Compound 3: only a limit was reported; the forecaster's own chance of this, stated with the estimate: 2%; middle value at least 3.5-fold (0.55 log units) from the limit.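

In this assay, the step at the sulfonamide nitrogen is large: 4-methoxyphenyl in place of 3-chlorophenyl gives an at least 12-fold higher number from compound 2 to compound 3 (1.10 log units; beyond the scatter), which shows that the number at this position is sensitive to this exchange of aryl groups. With hydrogen in place of methoxy on an aromatic carbon, the result is an at least 1.6-fold higher number from compound 1 to compound 3 (0.21 log units; that floor lies within the scatter), and because that floor lies within the scatter, it does not by itself separate the two compounds. The reading for compound 3 is a limit and not a number, so both steps are floors: the limit of > 1000 nM in this assay, at which 1 of the 3 values shown sits.

On these data alone, how far the true value of compound 3 lies from its limit remains open. As far as these compounds go, it also remains open what 4-chlorophenyl, unsubstituted phenyl or an aryl group carrying an amine would give on this nitrogen.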